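The source may hold more compounds than are shown below. What is called first, only, known or untested is meant among the compounds shown, and "the series" means these compounds.

Compounds measured:
- Compound 1, `O=C(/C=C/c1ccc([N+](=O)[O-])o1)c1ccc(Cl)cc1`: 558000 nM
- Compound 2, `O=C(/C=C/c1ccc([N+](=O)[O-])o1)c1ccc(Cl)cc1Cl`: 417000 nM
- Compound 3, `COc1ccc(COc2ccc(C(=O)/C=C/c3ccc([N+](=O)[O-])o3)cc2)cc1`: 311000 nM

In a toxicity assay on Vero cells (Chlorocebus sabaeus) for cytotoxicity (on this read-out higher numbers stand for lower toxicity in this test and lower numbers for higher toxicity in this test), compound 1 gives the highest of the three numbers, though its gaps to compound 2 and to compound 3 both lie within the scatter, so the three cannot be ranked. Compound 4, `O=C(/C=C/c1ccc([N+](=O)[O-])o1)c1ccc(N2CCCCC2)cc1`, is not yet measured; it differs from compound 1 by piperidin-1-yl in place of chloro on an aromatic carbon. Going by the values given here, the only step measured at that position, a 1.3-fold lower number from compound 1 to compound 2 (0.13 log units; within the scatter), stayed within the scatter, and no measured step puts a piperidin-1-yl group anywhere, so nothing bears directly on this change. A step no larger than the scatter is therefore expected, a 1.5-fold lower number from compound 1 to compound 4 (0.17 log units; within the scatter), and compound 4 is estimated at 380000 nM, with a range from 120000 nM to 900000 nM.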

Compound 4, half-maximal cytotoxic concentration: 349000 nM
The estimate for compound 4 lay 1.1-fold (0.04 log units) above the measured number; the range from low to high includes it.
By their numbers in this assay, from the lowest: compounds 3, 4, 2 and 1 (each within the scatter of the next).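

Placing piperidin-1-yl in place of chloro, on the carbon para to a large group, gives a 1.6-fold lower number from compound 1 to compound 4 (0.20 log units; within the scatter) in this assay. This position therefore accepts a much larger group that carries a six-membered non-aromatic ring and a ring nitrogen, with no change in this test beyond the scatter. No available evidence bears on this result. Still open, on these data alone, is whether a carboxylic acid or a primary amine at this position would also stay within the scatter, and whether a longer chain ending in piperidin-1-yl would do so.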